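A few compounds are considered here, and "the series" means these few. Any claim that something is new, unique, unknown or untested is made for them only; others in the source may bear on it.

Of the compounds shown here, three with a shared core have been measured. Compound 1 `CCOC(=O)[C@H](CCC(=O)O)NC(=O)c1ccc(Sc2nc3cc(N)cc(N)c3nc2-c2ccccc2)cc1` carries a sulfur-linked side arm bearing an ester and an acid; in a functional assay on SF-295 cells (Homo sapiens) for inhibition, read by sulforhodamine B assay, with a stated time of 48 h (on this read-out higher numbers stand for weaker inhibition of growth and lower numbers for stronger inhibition of growth), compound 1 gives 25100 nM. Compound 2 `Nc1cc(N)c2nc(-c3ccccc3)c(NCc3ccc(F)cc3)nc2c1` carries a (4-fluorobenzyl)amino group, and in this assay compound 2 gives 3470 nM, the lowest of the three numbers. Compound 3 `COc1ccc(CNc2nc3cc(N)cc(N)c3nc2-c2ccccc2)cc1` carries a methoxy in place of that fluoro, and in this assay compound 3 gives 17800 nM. Within the data shown here, the only step between measured compounds that differ in one place is a 5.1-fold higher number from compound 2 to compound 3 (0.71 log units; beyond the scatter).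

Compound 4 `Nc1cc(N)c2nc(-c3ccccc3)c(Sc3ccc(F)cc3)nc2c1` differs from compound 2 by (4-fluorophenyl)sulfanyl in place of (4-fluorobenzyl)amino on an aromatic carbon. Among the measured compounds shown here, no measured pair differs in just this way: the one measured step swaps a substituent on the outer ring, not the group that joins that ring to the core. For the measured compounds named here, compound 1 is the only other member joined through sulfur, but it also carries a much larger side arm, so its number shows only that a sulfur-joined compound in this set can sit well above compound 2. On that thin basis a modest weakening is expected, the step of a 2.3-fold higher number from compound 2 to compound 4 (0.36 log units; beyond the scatter). Compound 4 is therefore estimated at 8000 nM, with a likely range from 2500 nM to 25000 nM.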

Compound 4, concentration for 50% growth inhibition: 13800 nM
Estimate against measurement, compound 4: 1.7-fold (0.24 log units) below; low and high end bracket the measured number.
By their numbers in this assay, from the lowest: compound 2; then compounds 4, 3 and 1 (each within the scatter of the next).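

Changing the link that joins the fluorinated ring to the shared core, rather than a substituent on that ring, gives a 4.0-fold higher number from compound 2 to compound 4 (0.60 log units; beyond the scatter) in this assay, so growth inhibition at this position depends on the link as well as on the ring's substituent. With the 4-fluorophenyl part kept, the change still involves more than one feature: sulfur replaces nitrogen, the carbon of the benzyl group is gone, and the entering group lacks the hydrogen-bond donor of the leaving group. The data shown do not separate these features, and no measurement here gives a reason for the shift.

A (4-fluorophenyl)amino group would keep the nitrogen link without the benzyl carbon, while a (4-fluorobenzyl)sulfanyl group would keep that carbon with a sulfur link, so this pair of groups could show which feature matters more. Also open, on these data alone, is whether an oxygen link, as in a (4-fluorophenyl)oxy group, would fit the same trend or behave differently from both the nitrogen and sulfur links.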